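The source may report more compounds than this note shows. Statements on the series, on what has been measured and on what is new or still open speak of the compounds shown alone.

Compound 2 `COc1ccc(S(=O)(=O)Nc2ccc(C)cc2Br)cc1N1CCNCC1` stands highest of the two numbers recorded so far in an assay on isolated protein for binding affinity to 5-hydroxytryptamine receptor 6 (Homo sapiens) (a higher number here means a weaker inhibitor, a lower number a stronger inhibitor), where compound 2 gives 7.94 nM. Among the measured compounds shown here, its nearest neighbour is compound 1 `COc1ccc(S(=O)(=O)Nc2cccc(Br)c2)cc1N1CCNCC1`, which in this assay gives 1.26 nM; the one measured step, a 6.3-fold higher number from compound 1 to compound 2 (0.80 log units; beyond the scatter), already lies beyond the usual scatter. Compound 3 `COc1ccc(S(=O)(=O)Nc2c(F)cc(Br)cc2F)cc1N1CCNCC1` has not yet been measured in this assay. It differs from compound 2 in one place: 4-bromo-2,6-difluorophenyl in place of 2-bromo-4-methylphenyl on a sulfonamide nitrogen. For the measured compounds named here, only the step from compound 1 to compound 2 bears on this change, and it too altered the substitution pattern of the ring on the sulfonamide nitrogen, giving a modest weakening. A comparable or somewhat smaller move is expected here, with the direction uncertain. For compound 3 the estimated value in this assay is 10 nM, within a range of 3 nM to 40 nM, which corresponds to an expected step of a 1.3-fold higher number from compound 2 to compound 3 (0.10 log units; within the scatter).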

Compound 3, inhibition constant: 158 nM
Compound 3: middle estimate off by 16-fold (1.20 log units), on the low side; the whole stated range lies below it.
By their numbers in this assay, from the lowest: compound 1; then compound 2; then compound 3.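

In this assay the ring on the sulfonamide nitrogen turns out to tolerate less than the modest earlier step suggested, since a 20-fold higher number from compound 2 to compound 3 (1.30 log units; beyond the scatter) is a large loss and a 130-fold higher number from compound 1 to compound 3 (2.10 log units; beyond the scatter) makes compound 3 the weakest of the three. All three rings carry one bromine, so its presence alone does not keep the number low once the ring is 4-bromo-2,6-difluorophenyl. Nothing available accounts for the size of this loss.

The compounds shown change the fluorine atoms and the substitution pattern together, so they leave open whether either alone would produce this loss. They also leave open how the ring would respond to an amino group or a nitrile in place of the bromine.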